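From pyridin-4-yl to tert-butoxycarbonyl: working notes on the series

The source may report more compounds than this note shows. Statements on the series, on what has been measured and on what is new or still open speak of the compounds shown alone.

In an ADME assay on the whole organism (strain Sprague-Dawley) for pharmacokinetics, with Rattus norvegicus as the target, read by LC-MS (a lower number here means that a smaller share of the oral dose reaches the circulation, a higher number that a larger share of the oral dose reaches the circulation), compound 2 `O=C1N(c2ccncc2)CCN1c1cccc2c1cnn2-c1ccccc1F` gives 28% and compound 1 `CC(Oc1nn(-c2ccccc2F)c2ccc(F)cc12)C(=O)N1CCOCC1` gives 27%, so the two stand within the scatter of each other. For the measured compounds named here, these two compounds differ in more than one place, so the series holds no measured single-place step to guide the next change. Compound 3 `CC(C)(C)OC(=O)N1CCN(c2cccc3c2cnn3-c2ccccc2F)C1=O` departs from compound 2 in one place: tert-butoxycarbonyl in place of pyridin-4-yl on an amide-type nitrogen in a ring. In short, tert-butoxycarbonyl stands in place of pyridin-4-yl on an amide-type nitrogen in a ring. Going by the values given here, with no measured step to lean on, a fall in this assay of about the size of the usual scatter is expected, and this direction is a judgement rather than a trend in the data. The estimated step is a number 10 percentage points lower from compound 2 to compound 3 (within the scatter). For compound 3 the expected value is 18%, with an estimated range of 5% to 35%.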

Compound 3, oral bioavailability: 100%
The estimate for compound 3 lay 82 percentage points below the measured number; measured number above the stated range.
By their numbers in this assay, from the lowest: compounds 1 and 2 (each within the scatter of the next); then compound 3.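

For the compounds shown here, the amide-type nitrogen in a ring now stands out as a position where the group carried matters a great deal: in this assay tert-butoxycarbonyl in place of pyridin-4-yl gives a number 72 percentage points higher from compound 2 to compound 3 (beyond the scatter) and is the only single-place step so far. Compound 1 and compound 2 differ in more than one place and so could not show this. No measurement at hand bears on what lies behind the rise.

Open, as far as these compounds go, is whether the step belongs to tert-butoxycarbonyl specifically or would also appear with a smaller acyl group such as acetyl, or with a simple methyl, on this nitrogen. Also open, from the compounds shown here alone, is what an amine or a carboxylic acid carried on a short chain at this place would give.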